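Open-chain ester versus six-membered lactone at the chain end

The source may hold more compounds than are shown below. What is called first, only, known or untested is meant among the compounds shown, and "the series" means these compounds.

Compound 1 `CC/C=C\[C@H](C)[C@H](OC(N)=O)[C@@H](C)[C@H](O)[C@@H](C)C/C(C)=C\[C@H](C)[C@@H](O)[C@@H](C)/C=C\[C@@H](O)C[C@H](O)[C@H](C)C[C@H](C)C(=O)OC` is taken as the reference. In a functional assay on A549 cells (Homo sapiens) for antiproliferative activity (on this read-out higher numbers stand for weaker inhibition of growth and lower numbers for stronger inhibition of growth), compound 1 gives 4000 nM. Compound 2 `CC/C=C\[C@H](C)[C@H](OC(N)=O)[C@@H](C)[C@H](O)[C@@H](C)C/C(C)=C\[C@H](C)[C@@H](O)[C@@H](C)/C=C\[C@H](O)C[C@@H]1CCC(=O)O1`, which closes the same end of the chain into a five-membered lactone, gives in this assay a value of 4000 nM, so compound 1 stands level with it within the scatter.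

Compound 3 `CC/C=C\[C@H](C)[C@H](OC(N)=O)[C@@H](C)[C@H](O)[C@@H](C)C/C(C)=C\[C@H](C)[C@@H](O)[C@@H](C)/C=C\[C@@H](O)C[C@@H]1OC(=O)[C@H](C)[C@@H](OC)[C@H]1C` carries the change (a group of 11 heavy atoms (8 carbon, 3 oxygen; one six-membered non-aromatic ring with 1 hetero atom) in place of a group of 11 heavy atoms (8 carbon, 3 oxygen; no ring), on a saturated chain carbon, two bonds along the chain from a double-bonded chain carbon and an oxygen on a saturated carbon). For the measured compounds named here, with no step between measured compounds available for this change, and the ring closure of compound 2 leaving the value unchanged at 4000 nM, the expected step of a 1.6-fold lower number from compound 1 to compound 3 (0.20 log units; within the scatter) is small, within the scatter or modestly stronger. Compound 3 is estimated at 2500 nM, with a range from 500 nM to 12000 nM.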

Compound 3, concentration for 50% growth inhibition: 6.5 nM
For compound 3 the middle estimate is 380-fold (2.59 log units) above the measured one; measured number outside the range, below it.
By their numbers in this assay, from the lowest: compound 3; then compounds 1 and 2 (each within the scatter of the next).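

In this assay the group with one six-membered non-aromatic ring with 1 hetero atom, replacing the ring-free group of equal heavy-atom count, gives a 620-fold lower number from compound 1 to compound 3 (2.79 log units; beyond the scatter) on the same saturated chain carbon. This place therefore responds strongly to the group it carries, which the level values of compound 1 and compound 2 did not reveal. Nothing available here accounts for the size of this step.

On these data alone, the ring, the loss of a hydrogen-bond donor and the added stereocentre all change together, and their separate shares stay open. As far as these compounds go, how a lactam, with nitrogen in place of the ring oxygen, would behave at this place also stays open.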